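Compound 4 against compounds 1 to 3 in the cytotoxicity series

A few compounds are considered here, and "the series" means these few. Any claim that something is new, unique, unknown or untested is made for them only; others in the source may bear on it.

Measured compounds and their numbers:
compound 1 `COc1ccc(-n2cc(-c3ccccc3)c(-c3ccc4c(c3)NC(=O)CO4)n2)cc1` gives 92.2%
compound 2 `O=C1COc2ccc(-c3nn(-c4ccc(Cl)cc4)cc3-c3ccccc3)cc2N1` gives 61.9%
compound 3 `O=C1COc2ccc(-c3nn(-c4cc(Cl)cc(Cl)c4)cc3-c3ccccc3)cc2N1` gives 90.3%

All three share one core and were read in a functional assay on DLD-1 cells (Homo sapiens) for cytotoxicity, read by colorimetric assay and MTT assay, with a stated time of 3 days, tested at 1 uM; on this read-out lower numbers stand for a stronger effect and higher numbers for a weaker effect at the one concentration tested. Compound 1 stands highest of the three numbers; the nearest is compound 3, with a number 1.9 percentage points lower from compound 1 to compound 3 (within the scatter), which is within the scatter, and the furthest is compound 2, with a number 30.3 percentage points lower from compound 1 to compound 2 (beyond the scatter), beyond the scatter. Between compounds 2 and 3 the step is a number 28.4 percentage points higher from compound 2 to compound 3 (beyond the scatter).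

Compound 4 `O=C1COc2ccc(-c3nn(-c4ccccc4)cc3-c3ccccc3)cc2N1` differs from compound 1 in one place: hydrogen in place of methoxy on an aromatic carbon. Among the measured compounds shown here, no measured pair makes exactly this exchange. For the measured compounds named here, the steps that bear on it are those touching the same aromatic carbon or the same aryl group on the nitrogen: a number 30.3 percentage points lower from compound 1 to compound 2 (beyond the scatter) shows that a single change at this carbon can move the number by a large amount, while a number 1.9 percentage points lower from compound 1 to compound 3 (within the scatter) shows a larger change on the same ring leaving the number where it stands. The direction for a hydrogen in place of methoxy is therefore uncertain. A step of modest size, more likely downward than upward, is expected from compound 1 to compound 4, namely a number 10.2 percentage points lower from compound 1 to compound 4 (beyond the scatter). Compound 4 is estimated at 82%, within a range from 58% to 100%.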

Compound 4, a percentage reported as activity, at one concentration (the size of the read-out at that concentration, not a potency): 77%
Estimate against measurement, compound 4: 5 percentage points above; the measured number falls inside the stated range.
By their numbers in this assay, from the lowest: compound 2; then compound 4; then compounds 3 and 1 (each within the scatter of the next).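

In this assay hydrogen in place of methoxy on the aromatic carbon gives a number 15.2 percentage points lower from compound 1 to compound 4 (beyond the scatter) while hydrogen in place of chloro gives a number 15.1 percentage points higher from compound 2 to compound 4 (beyond the scatter) so this carbon now has an unsubstituted reference, with the number for hydrogen lying under that for methoxy and over that for chloro. The earlier compounds shown here could compare methoxy and chloro only with each other; compound 4 shows that the two groups move the number in opposite directions from hydrogen, and that the effect seen with chloro in compound 2 is a gain over the unsubstituted phenyl. The step from the other side, phenyl in place of 3,5-dichlorophenyl, gives a number 13.3 percentage points lower from compound 3 to compound 4 (beyond the scatter) so the two chlorinated rings also fall on opposite sides of phenyl, and chlorination of this ring has no single direction across compounds 2 and 3.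

On these data alone, whether a fluoro, methyl, amino or carboxylic acid group at this carbon would fall on the side of chloro or of methoxy remains open, as does the effect of a single chloro at other ring carbons. No measurement in hand accounts for the direction or the size of these steps.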